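The compounds below may be only part of what the source reports. "The series", "measured", "known", "first", "only" and "open" are said of these compounds alone.

Compound 1 `CC1(C[C@@H](O)C(=O)N2N=CC[C@H]2C(=O)NCc2cc(Cl)ccc2-n2cnnn2)CC1`: < 12 mL.min-1.g-1
Compound 2 `O=C(NCc1cc(Cl)ccc1-n1cnnn1)[C@@H]1CC=NN1C(=O)[C@H](O)C1CCCCC1`: 63 mL.min-1.g-1
Compound 3 `O=C(NCc1cc(Cl)ccc1-n1cnnn1)[C@@H]1CCNN1C(=O)[C@H](O)c1ccccc1`: < 16 mL.min-1.g-1

Within the data shown here, in an ADME assay on liver for metabolic stability, with Liver microsome (Homo sapiens) as the target, read by LC-MS, using microsomes (a lower number here means slower removal, a higher number faster removal of the compound), compound 2 gives 63 mL.min-1.g-1, the only number among the three measurements. For compound 1 the result is a limit of the assay, < 12 mL.min-1.g-1. For compound 3 the result is likewise a limit, < 16 mL.min-1.g-1.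

Compound 4 `O=C(NCc1cc(Cl)ccc1-n1cnnn1)[C@@H]1CC=NN1C(=O)[C@H](O)Cc1ccccc1` is compound 2 with one change: benzyl in place of cyclohexyl on a saturated chain carbon bound to a carbonyl carbon and an oxygen on a saturated carbon. Among the measured compounds shown here, only one measured step touches the same position. That step, an at least 5.2-fold higher number from compound 1 to compound 2 (0.72 log units; beyond the scatter), swaps in the cyclohexyl group that compound 4 now loses, and it was at least modest; because one end of it sits at the limit of < 12 mL.min-1.g-1 in this assay, at which 1 of the 3 values shown sits, its true size is not fully known. For the measured compounds named here, nothing among the measured compounds shows cyclohexyl giving way to benzyl, so the direction for compound 4 rests on that single step alone: the cyclohexyl of compound 2 carries the one number that is clearly above both limits, and replacing it is expected to pull the clearance back toward them rather than push it further up.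

The expected step is therefore a 1.8-fold lower number from compound 2 to compound 4 (0.26 log units; within the scatter), a modest decrease. Compound 4 is estimated at 35 mL.min-1.g-1, with a range from 14 mL.min-1.g-1 to 90 mL.min-1.g-1.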

Compound 4, intrinsic clearance in microsomes: < 12 mL.min-1.g-1
Compound 4: a limit, no number; the forecaster's own chance of this, stated with the estimate: 20%; middle value at least 2.9-fold (0.46 log units) away from the limit.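

In this assay, benzyl in place of cyclohexyl gives an at least 5.2-fold lower number from compound 2 to compound 4 (0.72 log units; beyond the scatter), so the high number of compound 2 does not carry over to this second replacement at the position on a saturated chain carbon bound to a carbonyl carbon and an oxygen on a saturated carbon. Among compound 1, compound 2 and compound 4, which share the same core, cyclohexyl is now the only group that gives a number rather than a limit, and the earlier step alone could not show this with only one other group for comparison. The full size of the new step remains unknown, because compound 4 gives a limit and not a number: the limit of < 12 mL.min-1.g-1 in this assay, at which 2 of the 4 values shown sit.

The step from compound 1 to compound 4 cannot be read, so the compounds shown do not order (1-methylcyclopropyl)methyl and benzyl at this position. They also leave open whether the high number follows the saturated ring or its direct attachment to the chain carbon, a question that a cyclohexylmethyl group at the same position would address.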